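Halogen swap on the fused ring of compound 3

The source may hold more compounds than are shown below. What is called first, only, known or untested is meant among the compounds shown, and "the series" means these compounds.

Compound 1, `Cc1cc(Nc2nc(NCc3ccc(C(F)(F)F)cc3)nc3ccccc23)n[nH]1`: 1400 nM in an assay for inhibition of high affinity nerve growth factor receptor (Homo sapiens), read by HTRF, with a stated time of 30 min, in the presence of a further agent that is not named here; on this read-out higher numbers stand for weaker inhibition and lower numbers for stronger inhibition
Compound 2, `Fc1ccc(CNc2nc(Nc3cc(C4CC4)[nH]n3)c3cc(F)ccc3n2)c(F)c1`: 59 nM in this assay
Compound 3, `Cc1cc(Nc2nc(NCc3ccc(F)cc3F)nc3cc(F)ccc23)n[nH]1`: 62 nM in this assay

Compound 3 sits in the same range as compound 2, the two numbers lying within the scatter of each other, and far below compound 1. Compound 4, `Cc1cc(Nc2nc(NCc3ccc(F)cc3F)nc3cc(Br)ccc23)n[nH]1`, differs from compound 3 in one place: bromo in place of fluoro on an aromatic carbon. Going by the values given here, no measured pair shows this swap, so its size is not known from the data. Compounds 2 and 3 both carry fluoro at the place in question and land near each other; compound 1 lacks it and stands far higher, which says nothing directly about bromo. The step of a 1.1-fold lower number from compound 3 to compound 4 (0.05 log units; within the scatter) is expected to stay within the scatter, in either direction. Compound 4 is estimated at 55 nM, with a range of 15 nM to 200 nM.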

Compound 4, half-maximal inhibitory concentration: 53 nM
Beside the measured number, compound 4's estimate is 1.0-fold (0.02 log units) above it; low and high end bracket the measured number.
By their numbers in this assay, from the lowest: compounds 4, 2 and 3 (each within the scatter of the next); then compound 1.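

Bromo in place of fluoro on this aromatic carbon gives a 1.2-fold lower number from compound 3 to compound 4 (0.07 log units; within the scatter) in this assay. This single pair shows that the position takes either halogen without a step beyond the scatter, so the larger bromo atom is accommodated here with no measurable loss in this assay. Nothing measured beyond these numbers bears on why the two halogens read alike. Still open, on these data alone, is how this position responds to a non-halogen group, such as methoxy, an amine or a carboxylic acid, and whether the result holds for a longer chain.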